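Halogen Swap on the Fused Ring of a Weak Inhibitor

A few compounds are considered here, and "the series" means these few. Any claim that something is new, unique, unknown or untested is made for them only; others in the source may bear on it.

Of the compounds shown here, two have been tested in an assay on isolated protein for inhibition of long-chain fatty acid transport protein 1 (Mus musculus); on this read-out lower numbers stand for stronger inhibition and higher numbers for weaker inhibition. Compound 1 `CCn1c(CNc2ccccc2)nnc1SCC(=O)Nc1ccc(Cl)cc1` gives > 10000 nM in this assay, which is a limit rather than a number. Compound 1 thus sits at the limit of > 10000 nM in this assay, at which 1 of the 2 values shown sits. Compound 2 `CCn1c(CNc2ccccc2)nnc1SCc1nc2cc(F)ccc2o1` gives 7800 nM in this assay, and it stands as the only numeric value among the two results shown.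

Compound 3 `CCn1c(CNc2ccccc2)nnc1SCc1nc2cc(Cl)ccc2o1` has not yet been measured. It differs from compound 2 by chloro in place of fluoro on an aromatic carbon of a six-membered aromatic ring of carbon only, part of a fused system of two rings. Among the compounds with values here, no step between two measured compounds is available to calibrate this change, so the expectation rests on compound 2 alone. The step from compound 2 to compound 3 is expected to be small, a 1.3-fold lower number from compound 2 to compound 3 (0.11 log units; within the scatter), and not clearly beyond the usual scatter in either direction. Compound 3 is therefore estimated to give about 6000 nM in this assay, with a plausible range from 2500 nM to 15000 nM.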

Compound 3, half-maximal inhibitory concentration: 2300 nM
Beside the measured number, compound 3's estimate is 2.6-fold (0.42 log units) above it; measured number below the stated range.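

In this assay, the change of halogen gives the series its first calibrated step, a 3.4-fold lower number from compound 2 to compound 3 (0.53 log units; beyond the scatter), so chloro in place of fluoro on an aromatic carbon is a change this read-out can register. Before this pair, no two measured compounds differed in one place, and nothing showed whether this position on the six-membered aromatic ring, part of a fused system of two rings, responded to substitution at all; it now does, even though one heavy atom replaces one heavy atom and the counts of hydrogen-bond donors and acceptors stay at zero on both sides. The compounds shown carry no measurement that would account for this step, so its cause remains unassigned.

This is a single pair, and it leaves open whether the trend from fluoro to chloro would continue with bromo or iodo, or whether a methyl, a methoxy, a nitrile or an amine at the same carbon would give a lower or a higher number. It also leaves open whether chloro in place of fluoro would have a step of similar size at another carbon of the same ring.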